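The compounds below may be only part of what the source reports. "The series", "measured", "known", "first", "only" and "open" are said of these compounds alone.

Three compounds have been measured in an ADME assay on isolated protein for inhibition of Amine oxidase [flavin-containing] B (Homo sapiens); on this read-out higher numbers stand for weaker inhibition and lower numbers for stronger inhibition:
compound 1 `C#CCNC1CCc2c(SCCc3ccc(Br)cc3)cccc21` gives 1250 nM;
compound 2 `C#CCNC1CCc2c(SCCc3ccc(C)cc3)cccc21` gives 4520 nM;
compound 3 `C#CCNC1CCc2c(SCCc3ccc(OC)cc3)cccc21` gives 4590 nM.

Compound 3 stands at the highest of the three numbers, though its gap to compound 2 is within the scatter, so the two cannot be ordered. Its gap to compound 1 is real: a 3.7-fold higher number from compound 1 to compound 3 (0.56 log units; beyond the scatter). All three share one core and differ only in the group on the aromatic carbon of the six-membered aromatic ring that sits para to a large group.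

Compound 4 `C#CCNC1CCc2c(SCCc3ccc(C(F)(F)F)cc3)cccc21` continues this series by the change (trifluoromethyl in place of methoxy on an aromatic carbon). For the measured compounds named here, the steps that bear on it are those that swapped this same para group: a 3.6-fold higher number from compound 1 to compound 2 (0.56 log units; beyond the scatter) and a 3.7-fold higher number from compound 1 to compound 3 (0.56 log units; beyond the scatter), both modest and beyond the scatter, while a 1.0-fold higher number from compound 2 to compound 3 (0.01 log units; within the scatter) was within the scatter. Going by the values given here, a trifluoromethyl has not yet been tried here, so no measured step points directly to its effect. The measured steps suggest that a change at this position moves the number in this assay by a modest amount at most, and a bromo gave the lower number in this set.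

Compound 4 is therefore expected to give 2500 nM, within 900 nM to 7000 nM, meaning an expected step of a 1.8-fold lower number from compound 3 to compound 4 (0.26 log units; within the scatter).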

Compound 4, half-maximal inhibitory concentration: 8780 nM
Compound 4: middle estimate off by 3.5-fold (0.55 log units), on the low side; the measured number lies above the stated range.
By their numbers in this assay, from the lowest: compound 1; then compounds 2, 3 and 4 (each within the scatter of the next).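

With trifluoromethyl, this position on the aromatic carbon para to a large group now carries a third group that cannot be told apart from the others in this assay: the step of a 1.9-fold higher number from compound 3 to compound 4 (0.28 log units; within the scatter) from methoxy and the step of a 1.9-fold higher number from compound 2 to compound 4 (0.29 log units; within the scatter) from methyl both stay inside the usual scatter. Bromo, by contrast, stands apart, and the step of a 7.0-fold higher number from compound 1 to compound 4 (0.85 log units; beyond the scatter) is the largest seen at this position so far, which leaves compound 1 alone as the strongest inhibitor of the four, with the three other groups forming one group of numbers that cannot be ordered. Nothing available explains why bromo alone separates from methyl, methoxy and trifluoromethyl in this way.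

The compounds shown leave open whether a chloro or an iodo on this carbon would give a number like that of compound 1 or fall in with the other three. They also leave open how an amine or a carboxylic acid at this position would read, and whether bromo would keep its place with a longer chain on the shared core.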